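Alkoxy versus alkylamino at the pyridine ring of compound 1

The source may hold more compounds than are shown below. What is called first, only, known or untested is meant among the compounds shown, and "the series" means these compounds.

The series shares one core and varies the group on an aromatic carbon. Compound 1 `CCCCN(C)c1nc(C(C)(C)C)ccc1CNC(=O)C(C)c1ccc(NS(C)(=O)=O)c(F)c1` gives 1.2 nM in an assay on cells for antagonist activity at transient receptor potential cation channel subfamily V member 1 (Homo sapiens), read by FLIPR and calcium flux, with a stated time of 6 min; a higher number here means a weaker inhibitor, a lower number a stronger inhibitor. Compound 2 `CC(C)Oc1nc(C(C)(C)C)ccc1CNC(=O)C(C)c1ccc(NS(C)(=O)=O)c(F)c1` gives 2.3 nM, and compound 3 `CC(C)CCOc1nc(C(C)(C)C)ccc1CNC(=O)C(C)c1ccc(NS(C)(=O)=O)c(F)c1` gives 0.8 nM. Compound 1 stands second highest of the three numbers; the step of a 1.5-fold lower number from compound 1 to compound 3 (0.18 log units; within the scatter) and the step of a 1.9-fold higher number from compound 1 to compound 2 (0.28 log units; within the scatter) both lie within the scatter, so the three are not ordered with confidence. Among the measured compounds shown here, only the step of a 2.9-fold lower number from compound 2 to compound 3 (0.46 log units; beyond the scatter) is beyond the scatter, and modest.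

Compound 4 `CC(C(=O)NCc1ccc(C(C)(C)C)nc1OC1CCCCC1)c1ccc(NS(C)(=O)=O)c(F)c1` is not yet measured. It differs from compound 1 as follows: cyclohexyloxy in place of butyl(methyl)amino on an aromatic carbon. For the measured compounds named here, the steps that bear on this are the two replacements of butyl(methyl)amino by an alkoxy group, a 1.9-fold higher number from compound 1 to compound 2 (0.28 log units; within the scatter) and a 1.5-fold lower number from compound 1 to compound 3 (0.18 log units; within the scatter), neither beyond the scatter. A cyclohexyloxy group is expected to behave like those alkoxy groups, so the step of a 1.1-fold lower number from compound 1 to compound 4 (0.04 log units; within the scatter) is expected to stay within the scatter. Compound 4 is therefore estimated at 1.1 nM, with a range of 0.4 nM to 3 nM.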

Compound 4, inhibition constant: 2.5 nM
Estimate against measurement, compound 4: 2.3-fold (0.36 log units) below; low and high end bracket the measured number.
By their numbers in this assay, from the lowest: compounds 3, 1, 2 and 4 (each within the scatter of the next, the first and the last beyond it).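

Cyclohexyloxy is the first replacement of butyl(methyl)amino on this aromatic carbon whose step lies beyond the scatter (a 2.1-fold higher number from compound 1 to compound 4 (0.32 log units; beyond the scatter)), though the step is modest. On the oxygen, cyclohexyl and isopropyl cannot be told apart (a 1.1-fold higher number from compound 2 to compound 4 (0.04 log units; within the scatter)), whereas the isopentyl of compound 3 is separated from cyclohexyl (a 3.1-fold higher number from compound 3 to compound 4 (0.49 log units; beyond the scatter)). Among the alkoxy groups, compound 3 therefore stands apart from both compound 2 and compound 4, and a ring on the oxygen offers no gain over the branched isopropyl group. Nothing on hand accounts for these differences.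

On these data alone, it remains open whether cyclopentyloxy would follow compound 4, or whether a longer chain such as hexyloxy would follow compound 3. Also open, as far as these compounds go, is whether a cyclic amine such as piperidine on this carbon would match compound 1.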